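The compounds below may be only part of what the source reports. "The series", "measured", "known", "first", "only" and "open" are said of these compounds alone.

Measured so far:
Compound 1 `c1cc(N2CCCCC2)nc(Nc2ccc(Oc3ncnc4sccc34)cc2)n1` gives 40.4% in a functional assay on MDA-MB-231 cells (Homo sapiens) for inhibition, read by MTT assay, with a stated time of 72 h, tested at 20 uM; on this read-out higher numbers stand for more inhibition at the one concentration tested (going by the name of the read-out) and lower numbers for less inhibition.
Compound 2 `CN(c1ccc(Oc2ncnc3ccsc23)cc1)c1nccc(N2CCCC2)n1` gives 38% in this assay.
Compound 3 `CN(c1ccc(Oc2ncnc3ccsc23)cc1)c1nccc(N2CCCCC2)n1` gives 49.7% in this assay.

Within the data shown here, compound 3 has the highest of the three numbers, but its gap to compound 1 lies within the usual scatter, so the two cannot be told apart; only compound 2 sits clearly lower, as the one measured step shows: a number 11.7 percentage points higher from compound 2 to compound 3 (beyond the scatter).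

Compound 4 `CN(c1ccc(Oc2ncnc3sccc23)cc1)c1nccc(N2CCCCC2)n1` keeps the shared core of compound 3 and differs from it in one place: a group of 9 heavy atoms (6 carbon, 2 nitrogen, 1 sulfur; one five-membered aromatic ring with 1 hetero atom, one six-membered aromatic ring with 2 hetero atoms) in place of a group of 9 heavy atoms (6 carbon, 2 nitrogen, 1 sulfur; one five-membered aromatic ring with 1 hetero atom, one six-membered aromatic ring with 2 hetero atoms), on an oxygen on an aromatic ring. Among the measured compounds shown here, no measured step covers this exchange. The step from compound 2 to compound 3 concerns a different part of the molecule. Compound 1 carries the same group that enters in compound 4, yet it differs from compound 3 in more than one place, so its value and that of compound 3 show only that the two lie within the scatter of each other.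

With nothing pointing either way, no step beyond the scatter is expected from compound 3 to compound 4, an estimated a number 3.7 percentage points lower from compound 3 to compound 4 (within the scatter). Compound 4 is therefore estimated at 46%, within a range of 30% to 62% in this assay.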

Compound 4, a percentage reported as inhibition, at one concentration (the size of the read-out at that concentration, not a potency): 29.3%
The estimate for compound 4 lay 16.7 percentage points above the measured number, outside the stated range (below it).
By their numbers in this assay, from the lowest: compounds 4, 2, 1 and 3 (each within the scatter of the next, the first and the last beyond it).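

In this assay the group on the oxygen matters even though its atoms do not change: the two groups have the same atom and ring counts, joined differently, yet the exchange gives a number 20.4 percentage points lower from compound 3 to compound 4 (beyond the scatter). Among these compounds, the same compound 4 also brings the first clean reading of the nitrogen on the aromatic ring, where methyl in place of hydrogen gives a number 11.1 percentage points lower from compound 1 to compound 4 (beyond the scatter), so that position responds too when this group is on the oxygen. Nothing measured here explains why either change lowers the number.

The compounds shown leave open whether methyl on that nitrogen has the same result with the group of compound 3. They also leave open how an ethyl group on that nitrogen, or a morpholine in place of the piperidin-1-yl, would read.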